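The source may report more compounds than this note shows. Statements on the series, on what has been measured and on what is new or still open speak of the compounds shown alone.

Measured compounds:
compound 1 `CC(C)N1CCN(Cc2cc(C(=O)N3CC(n4cnc5c(N)ncnc54)C3)nn2C)CC1`, 760 nM
compound 2 `Cc1nc(N)c2ncn(C3CN(C(=O)c4ccn(CC5CCN(C6CCCCCC6)CC5)c4)C3)c2n1`, 23 nM

Both compounds were tested in an assay on Sf9 cells for inhibition of N-lysine methyltransferase SMYD2 (Homo sapiens), read by scintillation proximity assay, with a stated time of 50 min, in the presence of a further agent that is not named here; on this read-out lower numbers stand for stronger inhibition and higher numbers for weaker inhibition. Compound 1 gives 760 nM, compound 2 gives 23 nM. Compound 2 thus holds the lower of the two numbers, and its gap to compound 1 lies beyond the usual scatter. The two differ in several places at once, so no single change can be read from them.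

Compound 3 `Cc1nc(N)c2ncn(C3CN(C(=O)c4ccn(CC5CCN(C6C=CCCCC6)CC5)c4)C3)c2n1` has not been measured. It differs from compound 2 in one place: cyclohept-2-en-1-yl in place of cycloheptyl on an amine nitrogen in a ring. The ring that leaves and the ring that enters have the same atom count; the only difference is the double bond outside aromatic rings. For the measured compounds named here, no measured pair shows the effect of such a change, so the expectation rests on compound 2 alone.

For compound 3 a step of about a 1.3-fold higher number from compound 2 to compound 3 (0.12 log units; within the scatter) is expected, that is, no change beyond the scatter. Compound 3 is estimated at 30 nM, with a range from 10 nM to 90 nM.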

Compound 3, half-maximal inhibitory concentration: 6 nM
Compound 3: middle estimate off by 5.0-fold (0.70 log units), on the high side; measured number outside the range, below it.
By their numbers in this assay, from the lowest: compound 3; then compound 2; then compound 1.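

Position: on an amine nitrogen in a ring, the seven-membered carbocycle responds to a very small edit. Under this assay, cyclohept-2-en-1-yl in place of cycloheptyl gives a 3.8-fold lower number from compound 2 to compound 3 (0.58 log units; beyond the scatter) on this single pair. Both groups have the same heavy-atom count, and the one counted difference is the double bond outside aromatic rings, yet the step lies beyond the scatter; nothing available accounts for this step.

Still open, as far as these compounds go, is whether the step follows from the double bond as such or from where it sits in the ring, as cyclohept-3-en-1-yl would show. Also open, from the compounds shown here alone, is whether a double bond has a similar effect in a smaller ring, such as cyclohex-2-en-1-yl in place of cyclohexyl.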